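A few compounds are considered here, and "the series" means these few. Any claim that something is new, unique, unknown or untested is made for them only; others in the source may bear on it.

Compound 2 `Nc1nc(Br)cn2cc(-c3ccco3)nc12` stands lowest of the two numbers in an assay on cells for displacement of a labelled ligand from transmembrane domain-containing protein TMIGD3 (Homo sapiens), read by scintillation counting, with a stated time of 120 min, tested at 1 uM; a higher number here means more inhibition at the concentration tested (going by the name of the read-out), a lower number less inhibition: compound 2 gives 28%, whereas compound 1 `Cc1ccc(C(=O)Nc2nccn3cc(-c4ccccc4)nc23)cc1` gives 45%, a gap beyond the usual scatter. Compound 3 `Nc1nc(-c2ccco2)cn2cc(-c3ccco3)nc12` differs from compound 2 by furan-2-yl in place of bromo on an aromatic carbon. Within the data shown here, no step between two measured compounds is known here, so the size of this change cannot be read from the data. A modest rise is expected, though one that may not exceed the scatter. Compound 3 is therefore estimated at 36%, between 15% and 60%. For compound 3 this means an expected step of a number 8 percentage points higher from compound 2 to compound 3 (within the scatter).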

Compound 3, a percentage reported as inhibition, at one concentration (the size of the read-out at that concentration, not a potency): 38%
For compound 3 the middle estimate is 2 percentage points below the measured one; the measured number falls inside the stated range.
By their numbers in this assay, from the lowest: compounds 2, 3 and 1 (each within the scatter of the next, the first and the last beyond it).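

In this assay, furan-2-yl in place of bromo on this aromatic carbon, next to the ring nitrogen, gives a number 10 percentage points higher from compound 2 to compound 3 (within the scatter). Among these compounds, this is the first step that can be read at this position, and it shows that a five-membered aromatic ring can take the place of a single bromine there without a change beyond the scatter. No available data give a reason for this result. Open, on these data alone, is whether an amine, a carboxylic acid or a longer chain on this carbon would move the number beyond the scatter.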